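Chloro Added Beside Trifluoromethyl: Expected Cytotoxicity Shift

This account rests on a few compounds, and the source may have more. Where it says the series, first, only, none or still open, it means among the compounds named here.

Compound 1 `Cc1cn(C2CCN(Cc3cccc(Oc4cc(C(F)(F)F)cc(C(F)(F)F)c4)c3)CC2)c(=O)[nH]c1=O`: "not determined" (no result reported)
Compound 2 `Cc1cn(C2CCN(Cc3cccc(Oc4cccc(C(F)(F)F)c4)c3)CC2)c(=O)[nH]c1=O`: 12400 nM
Compound 3 `Cc1cn(C2CCN(Cc3cccc(Oc4ccc(O)cc4)n3)CC2)c(=O)[nH]c1=O`: "not determined" (no result reported)

Within the data shown here, in an ADME assay on MRC5 cells (Homo sapiens) for cytotoxicity, read by fluorescence and resazurin assay, with a stated time of 3 days (a lower number here means a stronger inhibitor, a higher number a weaker inhibitor), compound 2 gives 12400 nM, the only number in this set. Compound 1 and compound 3 carry no result in this assay, so nothing can be said about how they compare. Compound 4 `Cc1cn(C2CCN(Cc3cccc(Oc4ccc(Cl)c(C(F)(F)F)c4)c3)CC2)c(=O)[nH]c1=O` has not yet been measured. It differs from compound 2 in one place: chloro in place of hydrogen on an aromatic carbon. Among the measured compounds shown here, with no measured step available, the size of the expected change rests on the structural change alone. The step from compound 2 to compound 4 is expected to be a 1.6-fold lower number from compound 2 to compound 4 (0.19 log units; within the scatter), toward a somewhat lower number, at or just beyond the usual scatter. Compound 4 is therefore estimated at 8000 nM, with a likely range from 3000 nM to 22000 nM.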

Compound 4, half-maximal inhibitory concentration: 5280 nM
Beside the measured number, compound 4's estimate is 1.5-fold (0.18 log units) above it, and the stated range covers the measured number.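

In this assay, among these compounds, the change gives a 2.3-fold lower number from compound 2 to compound 4 (0.37 log units; beyond the scatter), the first measured step in this set. It shows that this position, ortho to a trifluoromethyl group and para to a large group, responds to chloro in place of hydrogen, with a modest move toward a lower number that lies beyond the scatter. No measurement at hand accounts for this shift.

The compounds shown leave open whether an amine or a methoxy group at this position would move the number in the same direction. They also leave open whether fluoro would give a step of similar size.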